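Phenoxyethyl Ether in Place of Pyridinylmethyl Ether

The source may report more compounds than this note shows. Statements on the series, on what has been measured and on what is new or still open speak of the compounds shown alone.

Among the compounds with values here, in a functional assay on a cell-free system (plasma, Homo sapiens) for inhibition, with Plasma (Rattus norvegicus) as the target (on this read-out lower numbers stand for stronger inhibition and higher numbers for weaker inhibition), compound 1 `Cc1c(OCc2cccnc2)ccc2c(N3CCNCC3)cc(=O)oc12` gives 1420 nM, the lowest of the two numbers known so far. In this assay compound 2 `Cc1c(OCc2ccccc2-c2ccccc2)ccc2c(N3CCNCC3)cc(=O)oc12` gives 23000 nM. Compound 3 `Cc1c(OCCOc2ccccc2)ccc2c(N3CCNCC3)cc(=O)oc12` is not yet measured; it differs from compound 1 by phenoxymethyl in place of pyridin-3-yl on a saturated chain carbon bound to an oxygen on an aromatic ring. Within the data shown here, no measured pair shows this change directly. The author expects a moderate step toward a higher number in this assay, beyond the scatter, because compound 2 gives 23000 nM. Compound 3 is expected to give about 4500 nM, between 1200 nM and 16000 nM. That corresponds to an expected step of a 3.2-fold higher number from compound 1 to compound 3 (0.50 log units; beyond the scatter).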

Compound 3, half-maximal inhibitory concentration: 14300 nM
Beside the measured number, compound 3's estimate is 3.2-fold (0.50 log units) below it; measured number inside the range.
By their numbers in this assay, from the lowest: compound 1; then compounds 3 and 2 (each within the scatter of the next).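

Exchanging (pyridin-3-yl)methyl for 2-phenoxyethyl gives, in this assay, a 10-fold higher number from compound 1 to compound 3 (1.00 log units; beyond the scatter), the first step read directly at this position. The change replaces the ring nitrogen and also adds the phenoxymethyl atoms, so this single step cannot show which of the two matters. Nothing shown here explains the step.

The compounds shown leave open how benzyl, which pairs the link of compound 1 with a carbon-only ring, would compare. They also leave open how 2-(pyridin-3-yloxy)ethyl, which pairs the link of compound 3 with the pyridine ring, would compare.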